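Methyl Placement on the Fused Ring of a Flavone Series

The source may report more compounds than this note shows. Statements on the series, on what has been measured and on what is new or still open speak of the compounds shown alone.

Measured so far:
compound 1, `O=c1cc(-c2ccccc2)oc2ccc(N3COc4ccccc4C3)cc12`: 34%
compound 2, `Cc1cccc2c1OCN(c1ccc3oc(-c4ccccc4)cc(=O)c3c1)C2`: 60.9%

In a functional assay on MCF7 cells (Homo sapiens) for inhibition, read by MTT assay, with a stated time of 48 h, tested at 15 ug/mL (a lower number here means less inhibition of growth, a higher number more inhibition of growth at the concentration tested), compound 1 gives 34%, the lower of the two numbers measured. Compound 2 differs from it by a methyl in place of hydrogen on an aromatic carbon, and the step of a number 26.9 percentage points higher from compound 1 to compound 2 (beyond the scatter) lies beyond the scatter. Compound 3, `Cc1ccc2c(c1)CN(c1ccc3oc(-c4ccccc4)cc(=O)c3c1)CO2`, is not yet measured. It differs from compound 1 by methyl in place of hydrogen on an aromatic carbon, the methyl now sitting on another aromatic carbon of the same fused system. Among the compounds with values here, the single step that bears on it, from compound 1 to compound 2, was modest and upward, so an increase in this assay is expected for compound 3 as well, though a methyl on a different carbon need not give the same size of step. Compound 3 is therefore estimated to reach 48%, within 30% to 66%, a step of a number 14 percentage points higher from compound 1 to compound 3 (beyond the scatter).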

Compound 3, percent growth inhibition at one concentration: 31%
For compound 3 the middle estimate is 17 percentage points above the measured one; measured number inside the range.
By their numbers in this assay, from the lowest: compounds 3 and 1 (each within the scatter of the next); then compound 2.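

On the aromatic carbon meta to a fused ring and para to a fused ring, methyl in place of hydrogen gives, in this assay, a number 3 percentage points lower from compound 1 to compound 3 (within the scatter). The same exchange of groups therefore does not give the same result at every carbon of this fused system: on the carbon carrying the methyl of compound 2 the outcome is a number 26.9 percentage points higher from compound 1 to compound 2 (beyond the scatter), which lies beyond the scatter, whereas the new step does not. Nothing measured here accounts for this contrast between the two carbons.

The compounds shown leave open whether a methoxy group, a chlorine atom or an amine on the carbon carrying the methyl of compound 3 would also stay within the scatter of compound 1. They also leave open how an ethyl chain on the carbon carrying the methyl of compound 2 would compare with compound 2 at 60.9%.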